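Branching the amide: acetyl to isopropylcarbonyl

This account rests on a few compounds, and the source may have more. Where it says the series, first, only, none or still open, it means among the compounds named here.

In a functional assay on L1210 cells (Mus musculus) for antiproliferative activity (a lower number here means a stronger inhibitor, a higher number a weaker inhibitor), the three measured compounds spread widely. Compound 1 `CC(=O)Nc1nc(CCl)c[se]1` gives only a limit of > 100000 nM and no number. Compound 2 `Nc1nc(CN=C=S)c[se]1` gives 21000 nM. Compound 3 `CC(=O)Nc1nc(CN=C=S)cs1` gives 5200 nM, the lowest of the two numbers; the nearest number, that of compound 2, stands higher by a gap beyond the scatter. One of the three values sits at the limit of the assay (the limit of > 100000 nM in this assay, at which 1 of the 3 values shown sits).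

Compound 4 `CC(C)C(=O)Nc1nc(CN=C=S)cs1` is not yet measured. It differs from compound 3 by isopropyl in place of methyl on a carbonyl carbon whose other neighbours are an amide-type nitrogen. Within the data shown here, no measured pair shows the effect of a change of this kind, so the size of the step is open. In this assay the step is expected to stay small, within the usual scatter, with no clear direction. The expected step of a 1.2-fold lower number from compound 3 to compound 4 (0.06 log units; within the scatter) reflects that. Compound 4 is therefore estimated at 4500 nM, with a range from 1500 nM to 14000 nM.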

Compound 4, half-maximal inhibitory concentration: 8200 nM
For compound 4 the middle estimate is 1.8-fold (0.26 log units) below the measured one; the measured number falls inside the stated range.
By their numbers in this assay, from the lowest: compounds 3 and 4 (each within the scatter of the next); then compound 2. At a limit, above all of these: compound 1.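

The first step read at this place, a 1.6-fold higher number from compound 3 to compound 4 (0.20 log units; within the scatter), comes from this assay and stays within the scatter. Among these compounds, the earlier compounds offered no pair differing in one place, so this is the first direct reading: on a carbonyl carbon whose other neighbours are an amide-type nitrogen, isopropyl with its 3 heavy atoms and methyl with its 1 cannot be told apart in this assay. Nothing measured here bears on the reason for this result.

The compounds shown leave open whether a longer chain, a phenyl ring or an amine on this carbonyl carbon would give a step beyond the scatter. They also leave open whether the change from acetyl to isopropylcarbonyl would read the same on the core of compound 1.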